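The source may report more compounds than this note shows. Statements on the series, on what has been measured and on what is new or still open speak of the compounds shown alone.

Measured compounds:
Compound 1 `Cc1ccccc1-n1nc(C)c2c1NC(=O)[C@H](C)S[C@@H]2c1ccc(-c2ccoc2)cc1`, 3500 nM; compound 2 `COc1ccc(C2SC(C)C(=O)Nc3c2c(C)nn3-c2ccccc2C)c(OC)c1`, 10500 nM; compound 3 `Cc1ccccc1-n1nc(C)c2c1NC(=O)[C@H](C)S[C@@H]2c1ccc(-c2cc3ccccc3o2)cc1`, 1500 nM.

In an assay on isolated protein for agonist activity at Bile acid receptor (Homo sapiens), read by AlphaScreen, with a stated time of 30 min (on this read-out higher numbers stand for an effect only at larger amounts of compound and lower numbers for an effect already at smaller amounts), compound 3 stands lowest of the three measured numbers; the nearest is compound 1, and the furthest is compound 2, whose value is far higher. Compound 4 `COc1ccc(Oc2ccc([C@H]3S[C@@H](C)C(=O)Nc4c3c(C)nn4-c3ccccc3C)cc2)cc1` differs from compound 3 by 4-methoxyphenoxy in place of 1-benzofuran-2-yl on an aromatic carbon. Among the measured compounds shown here, the only measured step at this position is a 2.3-fold lower number from compound 1 to compound 3 (0.37 log units; beyond the scatter), which shows that the group here can shift the read-out modestly. For the measured compounds named here, no step involving an aryl ether is available, so the change is expected to be roughly neutral to slightly weakening, with a 1.7-fold higher number from compound 3 to compound 4 (0.22 log units; within the scatter). Compound 4 is therefore estimated at 2500 nM, with a range from 800 nM to 8000 nM.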

Compound 4, half-maximal effective concentration: 2200 nM
The estimate for compound 4 lay 1.1-fold (0.06 log units) above the measured number; the measured number falls inside the stated range.
By their numbers in this assay, from the lowest: compounds 3, 4 and 1 (each within the scatter of the next, the first and the last beyond it); then compound 2.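

In this assay, the first aryl ether at this position could not be separated from either earlier aromatic group: the data show a 1.5-fold higher number from compound 3 to compound 4 (0.17 log units; within the scatter), and a 1.6-fold lower number from compound 1 to compound 4 (0.20 log units; within the scatter). Compounds 1 and 3 differ beyond the scatter, yet compound 4 lies within the scatter of both, so 4-methoxyphenoxy cannot be ranked against either group. Nothing measured here accounts for this result. On these data alone, it remains open whether an amine or a carboxylic acid at this position would shift the number, and whether a longer chain in place of the methoxy group would do so.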